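This account rests on a few compounds, and the source may have more. Where it says the series, first, only, none or still open, it means among the compounds named here.

Measured compounds:
compound 1 `C=CC(=O)N1CC(NC(=O)Cn2cc(C(=O)N(C)Cc3ccccc3)c3cc(Br)ccc32)C1` — 1.67 h
compound 2 `C=CC(=O)N1CC(NC(=O)Cn2c(C)c(C(=O)N3CCc4c(cccc4OC)C3)c3cc(Br)ccc32)C1` — 1.67 h
compound 3 `C=CC(=O)N1CC(NC(=O)Cn2ccc3cc(Br)ccc32)C1` — 1.67 h

All three were read in a physicochemical assay for pharmacokinetics, read by LC-MS, in phosphate buffer, at pH 7.4, in the presence of a further agent that is not named here; on this read-out lower numbers stand for a shorter-lived compound and higher numbers for a longer-lived compound. Compound 1 stands level with compounds 2 and 3 at the digits shown: in this assay compound 1 gives 1.67 h, compound 2 gives 1.67 h and compound 3 gives 1.67 h. Going by the values given here, the single recorded step, no change at the digits printed from compound 1 to compound 3 (within the scatter), puts hydrogen in place of benzyl(methyl)carbamoyl on an aromatic carbon and leaves the read-out unmoved.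

Compound 4 `C=CC(=O)N1CC(NC(=O)Cn2cc(C(=O)N3CCc4cc(Cl)ccc4C3)c3cc(Br)ccc32)C1` has not yet been measured. It differs from compound 1 by a group of 11 heavy atoms (9 carbon, 1 nitrogen, 1 chlorine; one six-membered non-aromatic ring with 1 hetero atom, one six-membered aromatic ring of carbon only) in place of a group of 9 heavy atoms (8 carbon, 1 nitrogen; one six-membered aromatic ring of carbon only), on a carbonyl carbon. Among the compounds with values here, no recorded step matches this change exactly; the one step that touches the same carbonyl-borne group is within the scatter, and the values of compounds 1, 2 and 3 give no sign that the group on that carbonyl moves this read-out. On the three compounds available, no step beyond the scatter is expected in this assay.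

Compound 4 is therefore estimated at 1.67 h, with a range of 0.9 h to 3.2 h. The expected step of no change at the digits printed from compound 1 to compound 4 (within the scatter) is within the scatter.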

Compound 4, half-life: 1.67 h
Estimate against measurement, compound 4: no gap at the digits printed; the measured number falls inside the stated range.
By their numbers in this assay, from the lowest: compounds 1, 2, 3 and 4 (each within the scatter of the next).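

In this assay the exchange on a carbonyl carbon whose other neighbours are aromatic carbon gives no change at the digits printed from compound 1 to compound 4 (within the scatter) and brings in a six-membered non-aromatic ring with 1 hetero atom, together with a chlorine, in place of benzyl(methyl)amino. The earlier step at this group, no change at the digits printed from compound 1 to compound 3 (within the scatter), replaced the whole carbamoyl with hydrogen, whereas this one keeps the carbonyl and exchanges only what it carries, so the read-out is now level for both kinds of change. No measurement on hand accounts for this level read-out.

Going by these compounds, whether a carboxylic acid or a primary amine carried on this carbonyl would shift the half-life stays open. Also open, on these data alone, is whether replacing the bromine of the shared core with hydrogen would leave the read-out level.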